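Oxan-3-yl for oxan-2-yl on a sulfonamide series

The compounds below may be only part of what the source reports. "The series", "measured", "known", "first", "only" and "open" are said of these compounds alone.

Measured in an ADME assay on MDCKII-LE cells (Canis lupus familiaris) for permeability, read by transwell migration, in the apical to basolateral direction; a higher number here means that the compound crosses the layer faster, a lower number that the compound crosses the layer more slowly:
Compound 1 `CC1(C)CO[C@H]1CN([C@H](CCC(F)(F)F)C(N)=O)S(=O)(=O)c1ccc(Cl)cc1`: 26.4 10^-6 cm/s
Compound 2 `NC(=O)[C@@H](CCC(F)(F)F)N(C[C@H]1CCCCO1)S(=O)(=O)c1ccc(Cl)cc1`: 13.4 10^-6 cm/s

Compound 2 gives 13.4 10^-6 cm/s in this assay and, of the two numbers at hand, stands within the scatter of compound 1. Among the measured compounds shown here, the only measured step is a 2.0-fold lower number from compound 1 to compound 2 (0.29 log units; within the scatter), for oxan-2-yl in place of 3,3-dimethyloxetan-2-yl on a saturated chain carbon bound to a sulfonamide nitrogen.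

Compound 3 `NC(=O)[C@@H](CCC(F)(F)F)N(C[C@@H]1CCCOC1)S(=O)(=O)c1ccc(Cl)cc1` has not yet been measured. It differs from compound 2 as follows: oxan-3-yl in place of oxan-2-yl on a saturated chain carbon bound to a sulfonamide nitrogen. In short, oxan-3-yl stands in place of oxan-2-yl, and the two compounds have the same atoms, joined differently. For the measured compounds named here, no measured pair tests this exact exchange, so the step from compound 1 is the only guide. That step replaced the whole ring and still stayed within the scatter, so compound 2 at 13.4 10^-6 cm/s serves as the anchor. The estimated step is a 1.0-fold lower number from compound 2 to compound 3 (0.01 log units; within the scatter), which means no expected change beyond the scatter, in either direction. Compound 3 is expected at 13 10^-6 cm/s, with 7 10^-6 cm/s to 24 10^-6 cm/s as the estimated range.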

Compound 3, apparent permeability: 18.4 10^-6 cm/s
Compound 3: middle estimate off by 1.4-fold (0.15 log units), on the low side; measured number inside the range.
By their numbers in this assay, from the lowest: compounds 2, 3 and 1 (each within the scatter of the next).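

In this assay the exchange of oxan-2-yl for oxan-3-yl on a saturated chain carbon bound to a sulfonamide nitrogen now has a direct measurement, with a 1.4-fold higher number from compound 2 to compound 3 (0.14 log units; within the scatter) for two compounds that have the same atoms, joined differently. The comparison with the 3,3-dimethyloxetan-2-yl group adds a 1.4-fold lower number from compound 1 to compound 3 (0.16 log units; within the scatter) and, with the earlier step also within the scatter, none of the three groups at this place is separated from the others by this read-out, a statement that holds for these three compounds only. Nothing measured here gives a reason for these numbers, and the result offers no explanation of its own.

The compounds shown all carry a saturated oxygen ring at this place, so they leave open whether oxan-4-yl, or a group of another kind such as an amine, a carboxylic acid or a longer chain, would stay equally close in this assay or move beyond the scatter. They also leave open whether the same indifference would hold if the 4-chlorophenyl sulfonyl part or the trifluoromethyl-ended chain of the shared core were changed.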